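The compounds below may be only part of what the source reports. "The series", "measured", "known", "first", "only" and "open" are said of these compounds alone.

Measured so far:
compound 1, `CC(C)(C)c1cccc(N2CCNCC2)n1`: > 300 mg/kg
compound 2, `CCCCCCCc1cccc(N2CCN(C)CC2)n1`: 30 mg/kg
compound 3, `CCCCCCCc1ccnc(N2CCNCC2)c1`: 30 mg/kg

In a functional assay on the whole organism with Mus musculus as the target, in the maximal electroshock model, with a stated time of 120 min (on this read-out lower numbers stand for an effect already at smaller amounts and higher numbers for an effect only at larger amounts of compound), compound 1 gives > 300 mg/kg, which is a limit of the assay and not a number. Compound 1 therefore stands at the limit of > 300 mg/kg in this assay, at which 1 of the 3 values shown sits, and its true position is not fixed. In this assay compound 2 gives 30 mg/kg. In this assay compound 3 gives 30 mg/kg. Compound 4 is `CCCCCc1cccc(N2CCNCC2)n1`; it differs from compound 1 by pentyl in place of tert-butyl on an aromatic carbon. Among the measured compounds shown here, no step between two measured compounds is known here. Because compound 2 gives 30 mg/kg and compound 3 gives 30 mg/kg, a step toward lower numbers beyond the scatter is expected. The expected step is an at least 5.0-fold lower number from compound 1 to compound 4 (0.69 log units; beyond the scatter). Compound 4 is estimated at 60 mg/kg, within 20 mg/kg to 200 mg/kg.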

Compound 4, minimum effective dose: 10 mg/kg
Estimate against measurement, compound 4: 6.0-fold (0.78 log units) above, outside the stated range (below it).
By their numbers in this assay, from the lowest: compound 4; then compounds 2 and 3 (each within the scatter of the next). At a limit, above all of these: compound 1.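

In this assay, among the compounds shown here, pentyl in place of tert-butyl on the aromatic carbon next to the ring nitrogen gives an at least 30-fold lower number from compound 1 to compound 4 (1.47 log units; beyond the scatter) and is the first step read at this position. The change therefore shows that the group held here can move the dose by far more than the scatter. The value of compound 1 is a limit of the assay and not a number, so the true step stays unfixed: the limit of > 300 mg/kg in this assay, at which 1 of the 4 values shown sits.

From the compounds shown here alone, it remains open whether the straight chain or the added carbon matters. Going by these compounds, how propyl, nonyl or an amine would read at this position also remains open.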